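A few compounds are considered here, and "the series" means these few. Any claim that something is new, unique, unknown or untested is made for them only; others in the source may bear on it.

For the measured compounds named here, compound 1, `NC1=NC2(CCSCC2)N(OCCCOc2cccc(Cl)c2)C(N)=N1`, is the only member of this small set with a number: in an assay on isolated protein for inhibition of Dihydrofolate reductase (Homo sapiens), read by spectrophotometry, using NADPH, with stated times of 5 s and 6 min, tested at 50 uM (a lower number here means a weaker effect, a higher number a stronger effect of the compound at the concentration tested), compound 1 gives 88.8%. Its positional isomer compound 2, `NC1=NC2(CCSCC2)N(OCCCOc2ccc(Cl)cc2)C(N)=N1`, carries the chloro on the same ring at a different carbon, but for compound 2 the entry in this assay reads "not determined" (no result reported), so compound 2 stands without a number. Compound 3, `COc1ccc(OCCCON2C(N)=NC(N)=NC23CCSCC3)cc1`, differs from compound 2 by methoxy in place of chloro on an aromatic carbon. Going by the values given here, with no step between measured compounds available, a move of modest size, if any, beyond the scatter is expected in either direction. Compound 3 is expected to give about 75% in this assay, within 40% to 95%.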

Compound 3, a percentage reported as inhibition, at one concentration (the size of the read-out at that concentration, not a potency): 86.6%
Estimate against measurement, compound 3: 11.6 percentage points below; the range from low to high includes it.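

In this assay, 4-methoxyphenyl in place of 3-chlorophenyl gives a number 2.2 percentage points lower from compound 1 to compound 3 (within the scatter), so the chloro of compound 1 is not needed for a read-out of this size. The change of group and place together leaves no difference that can be told from the scatter, while the direct chloro to methoxy step cannot be read without a number for compound 2. Nothing available here bears on why the two compounds read alike. The compounds shown leave open the effect of methoxy and of ring position taken separately. They also leave open what an amine, a carboxylic acid or a longer chain would do.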